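The source may hold more compounds than are shown below. What is called first, only, known or untested is meant among the compounds shown, and "the series" means these compounds.

In a functional assay on A2780 cells (Homo sapiens) for cytotoxicity (on this read-out lower numbers stand for stronger inhibition and higher numbers for weaker inhibition), compound 3 (`CC(=O)Oc1cc(O)cc(CCCCCCC/C=C\CCCCCCCc2cc(O)cc(O)c2)c1`) gives 10.2 ug/mL and stands level with compound 2 (`Oc1cc(O)cc(CCCCCCC/C=C\CCCCCCCc2cc(O)cc(O)c2)c1`) at 10.2 ug/mL while compound 1 (`COc1cc(O)cc(CCCCCCC/C=C\CCCCCCCc2cc(O)cc(OC)c2)c1`) at 9.8 ug/mL lies within the scatter of both. The next entry is compound 4 (`COc1cc(O)cc(CCCCCCC/C=C\CCCCCCCc2cc(O)cc(O)c2)c1`), which takes methyl in place of acetyl on an oxygen on an aromatic ring. For the measured compounds named here, one measured step bears directly on this oxygen (no change at the digits printed from compound 2 to compound 3 (within the scatter)), with acetyl in place of hydrogen, and it stayed within the scatter. Compound 1 adds indirect evidence: it carries methyl on such oxygens where compound 2 carries hydrogen, and the values of compound 2 at 10.2 ug/mL and compound 1 at 9.8 ug/mL lie within the scatter of each other. Hydrogen, acetyl and methyl on this kind of oxygen have thus far given no separation in this assay, though only these few compounds speak to it. No shift beyond the scatter is therefore expected, in either direction, and the estimated step is small (a 1.0-fold lower number from compound 3 to compound 4 (0.01 log units; within the scatter)). For compound 4 the expected value is about 10 ug/mL within an estimated range (6 ug/mL to 16 ug/mL).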

Compound 4, half-maximal inhibitory concentration: 10 ug/mL
Compound 4: the middle estimate sits on the measured number at the digits printed; the range from low to high includes it.
By their numbers in this assay, from the lowest: compounds 1, 4, 2 and 3 (each within the scatter of the next).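

In this assay, for the compounds shown here, the exchange of acetyl for methyl on an oxygen on an aromatic ring now has a direct reading (a 1.0-fold lower number from compound 3 to compound 4 (0.01 log units; within the scatter)), where earlier only the step from hydrogen to acetyl bore on this oxygen. Methyl and hydrogen can also be compared in both directions around compound 4: methyl in place of hydrogen gives (a 1.0-fold lower number from compound 2 to compound 4 (0.01 log units; within the scatter)), and hydrogen in place of methyl gives (a 1.0-fold higher number from compound 1 to compound 4 (0.01 log units; within the scatter)). Hydrogen, acetyl and methyl thus form a closed set of comparisons on this oxygen, and every step among the four compounds stays within the scatter, so no substituent in this small set separates from the others.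

The compounds shown leave open whether a larger or charged group on this oxygen, such as benzyl, a longer acyl chain, an aminoalkyl group or a carboxylic acid, would move the number beyond the scatter. They also leave open whether the long chain of the shared core has more influence on this read-out than the groups on this oxygen. No measurement at hand explains why these steps remain so small.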